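A Cyano Group Replaces Methyl on Compound 3

The source may hold more compounds than are shown below. What is called first, only, known or untested is meant among the compounds shown, and "the series" means these compounds.

Of the compounds shown here, three sharing one core have been tested in a functional assay on DU-145 cells (Homo sapiens) for cytotoxicity, read by sulforhodamine B assay, with a stated time of 48 h; a higher number here means a weaker inhibitor, a lower number a stronger inhibitor. Compound 1 `C[C@H]1CC[C@@H]2[C@@H](OC(=O)[C@]23CC(c2ccc(O)cc2)=NO3)[C@]2(C)C(=O)C=C[C@@]12O` gives 93000 nM, compound 2 `COc1cc(C2=NO[C@]3(C2)C(=O)O[C@@H]2[C@H]3CC[C@H](C)[C@]3(O)C=CC(=O)[C@@]23C)ccc1O` gives 71000 nM, and compound 3 `Cc1ccc(C2=NO[C@]3(C2)C(=O)O[C@@H]2[C@H]3CC[C@H](C)[C@]3(O)C=CC(=O)[C@@]23C)cc1` gives 14000 nM. Compound 3 therefore has the lowest number of the three and is the strongest inhibitor so far. The first two sit close together, with a 1.3-fold lower number from compound 1 to compound 2 (0.12 log units; within the scatter). Methyl in place of hydroxy on an aromatic carbon gave a larger, modest step, a 6.6-fold lower number from compound 1 to compound 3 (0.82 log units; beyond the scatter). Replacing 4-hydroxy-3-methoxyphenyl with 4-methylphenyl gave a similar one, a 5.1-fold lower number from compound 2 to compound 3 (0.71 log units; beyond the scatter).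

Compound 4 `C[C@H]1CC[C@@H]2[C@@H](OC(=O)[C@]23CC(c2ccc(C#N)cc2)=NO3)[C@]2(C)C(=O)C=C[C@@]12O` keeps the core but carries cyano in place of methyl on an aromatic carbon, para to a large group (cyano in place of methyl on an aromatic carbon). Within the data shown here, no measured compound carries cyano, so the data offer only indirect guidance. Both modest steps involved losing a hydroxy group, and no hydroxy group changes here, so a smaller step is expected. The estimated change in this assay is a 1.4-fold higher number from compound 3 to compound 4 (0.15 log units; within the scatter). For compound 4 the estimated value is 20000 nM, with an expected range of 6000 nM to 60000 nM.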

Compound 4, half-maximal inhibitory concentration: 26000 nM
For compound 4 the middle estimate is 1.3-fold (0.11 log units) below the measured one, and the stated range covers the measured number.
By their numbers in this assay, from the lowest: compounds 3 and 4 (each within the scatter of the next); then compounds 2 and 1 (each within the scatter of the next).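

Among these compounds, at this position on the aromatic ring, para to a large group, methyl is not the only group compatible with the lower numbers: in this assay, cyano in place of methyl gives a 1.9-fold higher number from compound 3 to compound 4 (0.27 log units; within the scatter), so the two groups cannot be told apart here. Compound 4 also keeps a clear difference from the compounds with a hydroxy on that ring, showing a 2.7-fold lower number from compound 2 to compound 4 (0.44 log units; beyond the scatter) and a 3.6-fold lower number from compound 1 to compound 4 (0.55 log units; beyond the scatter), so among these four compounds, both without that hydroxy have the lower numbers. No measured evidence here explains this pattern.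

The compounds shown leave open how an amine, a carboxylic acid or a longer chain would read at this position. They also leave open whether plain hydrogen there would match methyl and cyano or the hydroxy compounds.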